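Aryl for benzyl on the triazole nitrogen, dipentylphenyl series

This account rests on a few compounds, and the source may have more. Where it says the series, first, only, none or still open, it means among the compounds named here.

Measured so far in a functional assay on SW-620 cells (Homo sapiens) for antiproliferative activity, read by MTT assay, with a stated time of 72 h; on this read-out higher numbers stand for weaker inhibition and lower numbers for stronger inhibition:
compound 1 `O=c1nc2oc(C3CC3)c(C#CC3CC3)c2cn1Cc1cn(Cc2ccccc2)nn1`: 9720 nM
compound 2 `O=c1nc2oc(CCCCl)c(C#CCCCCl)c2cn1Cc1cn(-c2ccc(Cl)cc2)nn1`: > 100000 nM, a limit of the assay
compound 3 `CCCCCc1ccc(C#Cc2c(-c3ccc(CCCCC)cc3)oc3nc(=O)n(Cc4cn(Cc5ccccc5)nn4)cc23)cc1`: > 100000 nM, a limit of the assay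

Compound 3 stands at the limit of this assay and carries no number. Compound 2 sits at the same limit (the limit of > 100000 nM in this assay, at which 2 of the 3 values shown sit). Going by the values given here, compound 1 is the only member with a numerical result, and no pair of measured compounds differs in a single place, so no measured step is available.

Compound 4 `CCCCCc1ccc(C#Cc2c(-c3ccc(CCCCC)cc3)oc3nc(=O)n(Cc4cn(-c5ccccc5F)nn4)cc23)cc1` differs from compound 3 in one place: 2-fluorophenyl in place of benzyl on an aromatic nitrogen. Compound 2, which also bears an aromatic ring rather than a benzyl on that aromatic nitrogen, gives only a limit, which offers no sign of a gain from this kind of replacement. With compound 3 already at the limit, the step of a number no higher from compound 3 to compound 4 (the limit leaves the size open) is expected to be none beyond the scatter, and compound 4 is most likely expected to return a limit as well. Estimate for compound 4 in this assay: 100000 nM, range 30000 nM to 300000 nM.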

Compound 4, half-maximal inhibitory concentration: 57100 nM
For compound 4 the middle estimate is 1.8-fold (0.24 log units) above the measured one; the range from low to high includes it.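

In this assay, going by these compounds alone, compound 4 gives 57100 nM, the only number so far among the compounds carrying the two pentyl-substituted phenyl groups, so the group on this aromatic nitrogen now has a measured value in that setting. Compound 3 gives > 100000 nM, which is a limit of the assay. The change from benzyl to 2-fluorophenyl therefore reads only as an at least 1.7-fold lower number from compound 3 to compound 4 (0.24 log units; that floor lies within the scatter), and its true size stays unknown, since the comparison rests on a limit: the limit of > 100000 nM in this assay, at which 2 of the 4 values shown sit.

The compounds shown do not separate the effect of the fluorine from that of losing the carbon link between the ring and the nitrogen. A plain phenyl or a 2-methoxyphenyl at this place, on the same dipentylphenyl compound, would bear on that question.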